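Sulfonamide glutamyl peptides: serine to glutamine swap

The source may report more compounds than this note shows. Statements on the series, on what has been measured and on what is new or still open speak of the compounds shown alone.

Three compounds sharing the core of compound 1 `CSCC[C@H](NC(=O)[C@H](CC(C)C)NC(=O)[C@H](CO)NC(=O)CC[C@H](NS(=O)(=O)c1ccc(Cl)c(C(F)(F)F)c1)C(=O)O)C(N)=O` have been run in an assay on isolated protein for inhibition of Matrilysin (Homo sapiens), read by fluorescence, with a stated time of 15 min; on this read-out lower numbers stand for stronger inhibition and higher numbers for weaker inhibition. Compound 1 gives 5700 nM, the second highest of the three numbers. Compound 2 `O=C(O)[C@H](CCc1ccccc1)NS(=O)(=O)c1ccc(Cl)c(C(F)(F)F)c1` gives 6100 nM, within the scatter of compound 1. Compound 3 `CC(C)C[C@H](NC(=O)CNC(=O)CC[C@H](NS(=O)(=O)c1ccc(Cl)c(C(F)(F)F)c1)C(=O)O)C(=O)N[C@H](C(=O)N1CCC[C@H]1C(N)=O)C(C)C` gives 19 nM, the lowest of the three and beyond the scatter from compound 1. Compound 4 `CSCC[C@H](NC(=O)[C@H](CC(C)C)NC(=O)[C@H](CCC(N)=O)NC(=O)CC[C@H](NS(=O)(=O)c1ccc(Cl)c(C(F)(F)F)c1)C(=O)O)C(N)=O` has not been measured in this assay; it differs from compound 1 by carbamoylmethyl in place of hydroxy on a saturated chain carbon, two bonds along the chain from an amide-type nitrogen and a carbonyl carbon. For the measured compounds named here, no measured pair isolates this change, so nothing shows its direction. The rest of compound 1 is unchanged, and the step is expected to fall near the scatter, a 1.4-fold lower number from compound 1 to compound 4 (0.15 log units; within the scatter). Compound 4 is estimated at 4000 nM in this assay, with a range from 1500 nM to 12000 nM.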

Compound 4, half-maximal inhibitory concentration: 1300 nM
The estimate for compound 4 lay 3.1-fold (0.49 log units) above the measured number; the whole stated range lies above it.
By their numbers in this assay, from the lowest: compound 3; then compound 4; then compounds 1 and 2 (each within the scatter of the next).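

In this assay carbamoylmethyl in place of hydroxy, on a saturated chain carbon two bonds along the chain from an amide-type nitrogen and a carbonyl carbon, gives a 4.4-fold lower number from compound 1 to compound 4 (0.64 log units; beyond the scatter) at this position. For the compounds shown here, this is the first measured step here, and it shows that the number responds to this side chain beyond the scatter, in the lower direction, with the larger group accepted. Nothing on hand explains the shift.

On these data alone, whether a carboxylic acid or an amine in place of the terminal carbamoyl group would go further stays open. So does the effect of a longer chain at this position.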